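Changing the Amide Substituent in a Weakly Antiproliferative Series

This account rests on a few compounds, and the source may have more. Where it says the series, first, only, none or still open, it means among the compounds named here.

Measured compounds:
compound 1 `COc1ccc(CNC(=O)c2cc(Oc3ccc(/C=C/c4ccccn4)cc3)ccn2)cc1`: 63600 nM
compound 2 `O=C(NCc1ccc(F)cc1)c1cc(Oc2ccc(/C=C/c3ccccn3)cc2)ccn1`: > 100000 nM

In a functional assay on A549 cells (Homo sapiens) for antiproliferative activity, read by CCK-8 assay, with a stated time of 48 h (on this read-out higher numbers stand for weaker inhibition and lower numbers for stronger inhibition), compound 1 gives 63600 nM. Compound 2 reaches only the limit of the assay, > 100000 nM, so no number is known for it. Among the compounds with values here, the single measured step, an at least 1.5-fold higher number from compound 1 to compound 2 (0.19 log units; that floor lies within the scatter), is small and lies within the scatter. Its size rests only on (the limit of > 100000 nM in this assay, at which 1 of the 2 values shown sits). Compound 3 `CC(C)NC(=O)c1cc(Oc2ccc(/C=C/c3ccccn3)cc2)ccn1` differs from compound 2 by isopropyl in place of 4-fluorobenzyl on an amide-type nitrogen. Within the data shown here, no measured step covers this kind of change, so the expectation rests solely on where compound 2 stands: at the upper edge of what this assay reports. Compound 3 is therefore expected to stay near that edge, with a number no higher from compound 2 to compound 3 (the limit leaves the size open) meaning no step beyond the scatter. The estimate for compound 3 is 100000 nM, with a range from 40000 nM to 300000 nM, and a real chance that only a limit is again reported.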

Compound 3, half-maximal inhibitory concentration: 21400 nM
Estimate against measurement, compound 3: 4.7-fold (0.67 log units) above, and the stated range ends above it.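

In this assay, the group on the amide nitrogen clearly affects the read-out: isopropyl in place of 4-fluorobenzyl gives an at least 4.6-fold lower number from compound 2 to compound 3 (0.66 log units; beyond the scatter), and isopropyl in place of 4-methoxybenzyl gives a 3.0-fold lower number from compound 1 to compound 3 (0.47 log units; beyond the scatter). Compound 2 stands at a limit of the assay, > 100000 nM, so the first of these steps gives only a floor: the limit of > 100000 nM in this assay, at which 1 of the 3 values shown sits. Both steps lie beyond the scatter, whereas the earlier change of methoxy to fluoro on the ring showed no step that could be told from the scatter, so among these three compounds, exchanging the whole benzyl group is the change that registers.

The compounds shown leave open whether the lower number comes from losing the aromatic ring or from shortening the group on the nitrogen. Also open, on these data alone, is how a methyl group, a longer chain such as butyl, or a chain ending in an amine would compare with isopropyl at this position.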